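The compounds below may be only part of what the source reports. "The series", "measured", "known", "first", "only" and "open" are said of these compounds alone.

Working notes on the sulfonamide-anilide series, cytotoxicity read-out.

Compound 1 `Cc1cc(NC(=O)c2ccc(C#N)cc2)ccc1NS(C)(=O)=O` in an ADME assay on HEK293 cells (Homo sapiens) for cytotoxicity, read by MTT assay, with a stated time of 48 h (on this read-out lower numbers stand for stronger inhibition and higher numbers for weaker inhibition), gives 43500 nM. Compound 2 `CCS(=O)(=O)Nc1ccc(NC(=O)c2ccc(C#N)cc2)cc1C` carries the same core with methyl in place of hydrogen on a saturated chain carbon bound to a sulfonyl sulfur. In this assay compound 2 reaches only the limit > 250000 nM. The step of an at least 5.7-fold higher number from compound 1 to compound 2 (0.75 log units; beyond the scatter) is therefore known only as a floor, due to the limit of > 250000 nM in this assay, at which 1 of the 3 values shown sits.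

Compound 3 `CS(=O)(=O)Nc1ccc(NC(=O)c2ccc(Cl)cc2)cc1F` belongs to a second core; the difference between the two cores is not broken down here. In this assay compound 3 gives 216000 nM, the highest of the two numbered values and beyond the scatter from compound 1.

Compound 4 `CCS(=O)(=O)Nc1ccc(NC(=O)c2ccc(Cl)cc2)cc1F` has not yet been measured in this assay. Relative to compound 3 it bears methyl in place of hydrogen on a saturated chain carbon bound to a sulfonyl sulfur, the same change seen between compound 1 and compound 2, at the same place. The step is expected to be a 2.8-fold higher number from compound 3 to compound 4 (0.44 log units; beyond the scatter), resting on an at least 5.7-fold higher number from compound 1 to compound 2 (0.75 log units; beyond the scatter). Since compound 3 already sits close to the limit of this assay, a limit rather than a number is thought more likely than not. For compound 4 the expected value is 600000 nM, within 150000 nM and 2500000 nM.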

Compound 4, half-maximal inhibitory concentration: 53400 nM
For compound 4 the middle estimate is 11-fold (1.05 log units) above the measured one; the measured number lies below the stated range.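

On the second core, methyl in place of hydrogen on a saturated chain carbon bound to a sulfonyl sulfur gives a 4.0-fold lower number from compound 3 to compound 4 (0.61 log units; beyond the scatter) in this assay. The same change therefore does not carry over from one core to the other in this series, since the two steps run in opposite directions: the same change on two cores in this assay, an at least 5.7-fold higher number (0.75 log units; beyond the scatter) from compound 1 to compound 2 and a 4.0-fold lower number (0.61 log units; beyond the scatter) from compound 3 to compound 4, at least 23-fold (1.36 log units) apart, beyond the scatter of two such steps

Compound 2 gives > 250000 nM, which is a limit and not a number, and with only one pair on each core the result does not show how large the gap truly is, or which difference between the cores goes with the reversal: the limit of > 250000 nM in this assay, at which 1 of the 4 values shown sits.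

As far as these compounds go, it remains open whether a longer chain, such as propyl in place of ethyl on the sulfonyl sulfur, would follow the direction seen on each core. Also open, from the compounds shown here alone, is whether the reversal follows the nitrile or the chlorine, or the methyl or the fluorine, which a core mixing these groups would help to separate.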